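One more methyl oxadiazole isomer awaits measurement

The compounds below may be only part of what the source reports. "The series", "measured", "known", "first", "only" and "open" are said of these compounds alone.

Measured so far in an ADME assay on the whole organism for pharmacokinetics, with Rattus norvegicus as the target; a lower number here means slower removal, a higher number faster removal of the compound:
- compound 1 `COc1ccc(C(=O)C2=C(O)C(=O)N(c3ccc(-c4noc(C)n4)cc3)C2C2CCCCC2)cc1` gives 5 mL/min/kg
- compound 2 `COc1ccc(C(=O)C2=C(O)C(=O)N(c3ccc(-c4nc(C)no4)cc3)C2C2CCCCC2)cc1` gives 3.4 mL/min/kg

Going by the values given here, compound 2 stands within the usual scatter of compound 1, the only other measured compound, so these two numbers cannot be told apart. The next structure, compound 3 `COc1ccc(C(=O)C2=C(O)C(=O)N(c3ccc(-c4nnc(C)o4)cc3)C2C2CCCCC2)cc1`, keeps the shared core and changes one group, with the same atoms joined differently: 5-methyl-1,3,4-oxadiazol-2-yl in place of 3-methyl-1,2,4-oxadiazol-5-yl on an aromatic carbon. In words, 5-methyl-1,3,4-oxadiazol-2-yl takes the place of 3-methyl-1,2,4-oxadiazol-5-yl on an aromatic carbon.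

Among the compounds with values here, only one measured step bears on this change. It is a 1.5-fold lower number from compound 1 to compound 2 (0.17 log units; within the scatter), an exchange between two other methyl oxadiazole isomers, also on an aromatic carbon. Within the data shown here, one step is thin evidence, and no compound carrying the 5-methyl-1,3,4-oxadiazol-2-yl group has a value yet. Even so, no shift beyond the scatter is expected in this assay for this new isomer.

The expected step is a 1.2-fold higher number from compound 2 to compound 3 (0.07 log units; within the scatter), which is an estimate and no more. For compound 3 the estimated value is 4 mL/min/kg, with an expected range from 1.8 mL/min/kg to 9 mL/min/kg.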

Compound 3, clearance: 5.5 mL/min/kg
Compound 3: middle estimate off by 1.4-fold (0.14 log units), on the low side; measured number inside the range.
By their numbers in this assay, from the lowest: compounds 2, 1 and 3 (each within the scatter of the next).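

In this assay the 5-methyl-1,3,4-oxadiazol-2-yl group now has a value of its own, and it gives a 1.6-fold higher number from compound 2 to compound 3 (0.21 log units; within the scatter) and a 1.1-fold higher number from compound 1 to compound 3 (0.04 log units; within the scatter) with both steps inside the scatter. Together with the earlier exchange, this means that all three methyl oxadiazole isomers, on an aromatic carbon para to a large group, cannot be told apart in this read-out, and none of the three compounds goes against that; before, only a single pair of isomers had been compared. The data at hand hold nothing that would explain why these isomers read alike.

All three compounds carry the same atoms in this group and the same shared core, so the result speaks only to rearranging those atoms and says nothing about what a change elsewhere in the core would do. On these data alone, it remains open whether a different group at this place, such as a carboxylic acid or a primary amine, or an ethyl or longer chain in place of the methyl on the oxadiazole, would move the number beyond the scatter.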